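Propyl in Place of Cyclopropyl on a Carbonyl Carbon

The source may hold more compounds than are shown below. What is called first, only, known or untested is meant among the compounds shown, and "the series" means these compounds.

Compound 1 `CC1=C(C(=O)OC(C)(C)C)C(c2ccoc2)NC(=O)N1` gives 11% in an assay on membranes from CHO cells for displacement of a labelled ligand from adenosine receptor A1 (Homo sapiens), read by scintillation counting, with a stated time of 60 min, tested at 1 uM; a higher number here means more inhibition at the concentration tested (going by the name of the read-out), a lower number less inhibition.
Compound 2 `CC(=O)C1=C(C)NC(=O)NC1c1ccoc1` gives 6% in this assay.
Compound 3 `CC1=C(C(=O)C2CC2)C(c2ccoc2)NC(=O)N1` gives 1% in this assay.

These three compounds share one core and differ only in the group attached to a carbonyl carbon. None of the three numbers is large, and they sit close together: the step of a number 5 percentage points lower from compound 1 to compound 2 (within the scatter) and the step of a number 10 percentage points lower from compound 1 to compound 3 (within the scatter) both lie within the scatter, as does the step of a number 5 percentage points lower from compound 2 to compound 3 (within the scatter). Compound 3 therefore cannot be set apart from compound 1 or compound 2 on these numbers; its value simply belongs to the same low cluster.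

Compound 4 `CCCC(=O)C1=C(C)NC(=O)NC1c1ccoc1` carries the next change at the same place: propyl in place of cyclopropyl on a carbonyl carbon. For the measured compounds named here, the steps that bear on this are those that also swapped the group on that carbonyl carbon, namely the steps from compound 1 and from compound 2 to compound 3, and neither of them moved the number beyond the scatter. Exchanging a three-carbon ring for a three-carbon chain there is expected to behave alike. The expected change, a number 3 percentage points higher from compound 3 to compound 4 (within the scatter), stays within the scatter. Compound 4 is thus estimated to give about 4%, in a range from -8% to 15%.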

Compound 4, a percentage reported as inhibition, at one concentration (the size of the read-out at that concentration, not a potency): 1%
Estimate against measurement, compound 4: 3 percentage points above, and the stated range covers the measured number.
By their numbers in this assay, from the lowest: compounds 3, 4, 2 and 1 (each within the scatter of the next).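

Replacing cyclopropyl with propyl on a carbonyl carbon gives, in this assay, no change at the digits printed from compound 3 to compound 4 (within the scatter) and thus shows that, at this place and in this low range, having a ring or an open chain of three carbons makes no readable difference. The open chain also cannot be told apart from the two other groups: ethyl in place of hydrogen on the saturated chain carbon bound to the carbonyl carbon gives a number 5 percentage points lower from compound 2 to compound 4 (within the scatter) and propyl in place of tert-butoxy gives a number 10 percentage points lower from compound 1 to compound 4 (within the scatter) in this comparison, so all four compounds now form a single low cluster with no order among them that the numbers can support. No measurement at hand offers an explanation for this flat picture.

Going by these compounds, what remains open is whether an amine or a longer chain such as hexyl on the same carbonyl carbon would lift the number clear of this cluster. On these data alone, it is also open whether any change elsewhere on the shared core would do so, as all four compounds keep that core the same.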